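The compounds below may be only part of what the source reports. "The series", "measured", "known", "first", "only" and "open" are said of these compounds alone.

In a functional assay on A549 cells (Homo sapiens) for antiproliferative activity, read by MTT assay, with a stated time of 72 h (on this read-out higher numbers stand for weaker inhibition and lower numbers for stronger inhibition), the measured compounds are:
Compound 1 `O=C1O[C@H]([C@@H](O)Cn2cc(-c3ccc(Br)cc3)nn2)C(OCc2ccccc2)=C1OCc1ccccc1`, which gives 750 nM.
Compound 2 `Cc1ccc(-c2cn(C/C=C3\OC(=O)C(OCc4ccccc4)=C3OCc3ccccc3)nn2)cc1`, which gives only a limit, > 100000 nM.

Compound 1 thus holds the single number shown in this assay; compound 2 stands at a limit of the assay, (the limit of > 100000 nM in this assay, at which 1 of the 2 values shown sits).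

Compound 3 `O=C1O[C@H]([C@@H](O)Cn2cc(-c3cccc(O)c3)nn2)C(OCc2ccccc2)=C1OCc1ccccc1` differs from compound 1 by 3-hydroxyphenyl in place of 4-bromophenyl on an aromatic carbon. Among the measured compounds shown here, no measured pair shows this change, so its size is unknown. Compound 3 is expected to be somewhat weaker than compound 1, with the step of a 2.0-fold higher number from compound 1 to compound 3 (0.30 log units; within the scatter) close to the scatter. Compound 3 is therefore estimated at 1500 nM, within 500 nM to 6000 nM.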

Compound 3, half-maximal inhibitory concentration: 59900 nM
For compound 3 the middle estimate is 40-fold (1.60 log units) below the measured one; measured number above the stated range.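

The aryl group on this aromatic carbon is not interchangeable on the shared core: in this assay, 3-hydroxyphenyl in place of 4-bromophenyl gives an 80-fold higher number from compound 1 to compound 3 (1.90 log units; beyond the scatter). Nothing measured here bears on the cause of this step.

The change alters both the substituent and where it sits on the phenyl ring, and the compounds shown cannot separate the two. As far as these compounds go, whether 3-bromophenyl or 4-hydroxyphenyl would stay close to compound 1 or fall toward compound 3 remains open, as does the effect of an amine such as 4-aminophenyl.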